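A few compounds are considered here, and "the series" means these few. Any claim that something is new, unique, unknown or untested is made for them only; others in the source may bear on it.

Compound 1 `CCN(CC)c1nc(C)c2[nH]c(SCC(=O)NCCN)[n+](CCCN(C)C)c2n1` gives > 100 uM in an ADME assay on CEM174 cells (Homo sapiens) for cytotoxicity; a lower number here means that less compound is tolerated, a higher number that more compound is tolerated; this is a limit of the assay. Compound 2 `CCN(CC)c1nc(C)c2[nH]c(SCC(=O)NCCCN)[n+](CCCN(C)C)c2n1` gives > 100 uM, again a limit. Compound 3 `CCN(CC)CC[n+]1c(SCC(=O)NCCCNC(=N)N)[nH]c2c(C)nc(N(CC)CC)nc21` gives > 100 uM, also a limit.

Compound 3 thus stands where every value shown stands: at the limit of > 100 uM in this assay, at which 3 of the 3 values shown sit. For the measured compounds named here, the one measured change, a step that the two limits leave unreadable from compound 1 to compound 2, cannot be read in size, since both ends are limits. Compound 4 `CCN(CC)c1nc(C)c2[nH]c(SCC(=O)NCCCNC(=N)N)[n+](CCCN(C)C)c2n1` differs from compound 3 by (dimethylamino)methyl in place of diethylamino on a saturated chain carbon, two bonds along the chain from an aromatic nitrogen. Going by the values given here, no measured step bears on this change, and none of the values gives a number to move from. The expectation for compound 4 is therefore a step that the limit leaves unreadable from compound 3 to compound 4 in this assay, none beyond the scatter. Compound 4 is estimated at 150 uM, with a range of 50 uM to 400 uM.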

Compound 4, half-maximal toxic concentration: > 100 uM
Compound 4: a limit, no number (the forecaster's own chance of this, stated with the estimate: 80%); the middle value does not contradict the limit.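

For the compounds shown here, no step among compound 1, compound 2, compound 3 and compound 4 can be read, since both ends of each step are limits: the limit of > 100 uM in this assay, at which 4 of the 4 values shown sit. The compounds shown leave open whether any of these changes shifts the tolerated concentration at all.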